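Nitro in place of amino on compound 2

A few compounds are considered here, and "the series" means these few. Any claim that something is new, unique, unknown or untested is made for them only; others in the source may bear on it.

Measured in a functional assay on MCF7 cells (Homo sapiens) for antiproliferative activity, read by MTT assay, with a stated time of 48 h; a higher number here means a weaker inhibitor, a lower number a stronger inhibitor:
compound 1 `COc1ccc2c(/C=C/C(=O)c3cc(N)c(OC)c(OC)c3)c[nH]c2c1`: 249 nM
compound 2 `COc1ccc2c(/C=C/C(=O)c3cc(N)c(OC)c(OC)c3)cn(C)c2c1`: 505 nM
compound 3 `COc1cc(C(=O)/C=C/c2cn(C)c3ccccc23)cc(N)c1OC`: 631 nM

Compound 2 holds the second highest number of the three. Compound 4 `COc1ccc2c(/C=C/C(=O)c3cc(OC)c(OC)c([N+](=O)[O-])c3)cn(C)c2c1` differs from it in one place: nitro in place of amino on an aromatic carbon. Neither measured step touches the amino group. These steps, a 2.0-fold higher number from compound 1 to compound 2 (0.31 log units; beyond the scatter) and a 1.2-fold higher number from compound 2 to compound 3 (0.10 log units; within the scatter), concern other places, so they show only the modest scale of change in this small series. Among the measured compounds shown here, no nitro compound has been measured yet, so direction and size remain a judgement. In this assay a moderate move to a higher number is expected, and the estimated step is a 2.6-fold higher number from compound 2 to compound 4 (0.41 log units; beyond the scatter). For compound 4 the estimate is 1300 nM, with an expected range of 350 nM to 5000 nM.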

Compound 4, half-maximal inhibitory concentration: 1520 nM
The estimate for compound 4 lay 1.2-fold (0.07 log units) below the measured number; the measured number falls inside the stated range.
By their numbers in this assay, from the lowest: compound 1; then compounds 2 and 3 (each within the scatter of the next); then compound 4.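

In this assay, among the compounds shown here, nitro in place of amino on the aromatic carbon ortho to a methoxy group gives a 3.0-fold higher number from compound 2 to compound 4 (0.48 log units; beyond the scatter) and is the first measured change at this position, which proves sensitive to this replacement. Activity falls but persists, with compound 4 at 1520 nM in the series. No measured evidence bears on the reason for this step.

Still open, going by these compounds, is whether hydroxyl, dimethylamino or an acetamide at this carbon would keep the number of compound 2. Also open, on these data alone, is whether the same replacement gives a similar step on compound 1 or compound 3.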